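A few compounds are considered here, and "the series" means these few. Any claim that something is new, unique, unknown or untested is made for them only; others in the source may bear on it.

In an ADME assay on the whole organism (Rattus norvegicus, strain Sprague-Dawley) for pharmacokinetics, read by LC-MS, with a stated time of 30 min (on this read-out lower numbers stand for narrower distribution and higher numbers for wider distribution into tissues), the measured compounds stand as follows:
- compound 1 `N#Cc1ccc(O[C@H]2CN(S(=O)(=O)c3ccc(C(F)(F)F)cc3)C[C@@]2(O)CO)cc1F` gives 5.9 L/kg
- compound 2 `N#Cc1ccc(O[C@H]2CN(S(=O)(=O)c3ccc(Cl)cc3Cl)C[C@@]2(O)CN)cc1F` gives 7.7 L/kg
- compound 3 `N#Cc1ccc(O[C@H]2CN(S(=O)(=O)c3ccc(Cl)cc3Cl)C[C@]2(O)CO)cc1F` gives 13 L/kg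

Compound 1 (5.9 L/kg) and compound 2 (7.7 L/kg) lie within the usual scatter of each other. Compound 3 (13 L/kg) stands higher than compound 1, and that gap lies beyond the scatter. Compound 1 therefore sits with compound 2 at the narrower end of these three numbers.

Compound 4 `N#Cc1ccc(O[C@H]2CN(S(=O)(=O)c3ccc(C(F)(F)F)nc3)C[C@@]2(O)CO)cc1F` keeps the core of compound 1 and changes one group, with 6-(trifluoromethyl)pyridin-3-yl in place of 4-(trifluoromethyl)phenyl on a sulfonyl sulfur. Among the compounds with values here, no pair of measured compounds shows this exchange, and compound 2 and compound 3 each differ from compound 1 in more than one place. Within the data shown here, the data therefore offer no measured step to lean on.

With compound 1 at (5.9 L/kg) as the anchor, a modest move toward narrower distribution in this assay is expected, and it should not exceed the scatter. The estimate is a step of a 1.4-fold lower number from compound 1 to compound 4 (0.14 log units; within the scatter) and the range is kept wide on either side of it. Compound 4 is estimated at 4.3 L/kg (expected range 2.2 L/kg to 8.5 L/kg).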

Compound 4, volume of distribution at steady state in the Rattus norvegicus assay: 4.1 L/kg
Compound 4: middle estimate off by 1.0-fold (0.02 log units), on the high side; the range from low to high includes it.
By their numbers in the Rattus norvegicus assay, from the lowest: compounds 4, 1, 2 and 3 (each within the scatter of the next, the first and the last beyond it).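

Within the data shown here, this pair gives the first clean reading of the group on a sulfonyl sulfur whose other neighbours are the sulfonamide nitrogen in a ring, since the earlier compounds each differed from compound 1 in more than one place. In the Rattus norvegicus assay, 6-(trifluoromethyl)pyridin-3-yl in place of 4-(trifluoromethyl)phenyl gives a 1.4-fold lower number from compound 1 to compound 4 (0.16 log units; within the scatter), so at this position the read-out does not separate the two rings. In a physicochemical assay for solubility, in simulated intestinal fluid, with a stated time of 4 h (a lower number here means a less soluble compound, a higher number a more soluble compound), however, with compound 1 at 5 ug/mL and compound 4 at 98 ug/mL the same exchange, which brings a ring nitrogen into the aromatic ring and leaves the trifluoromethyl group in place, goes with a large step that the distribution read-out does not show: the measured solubility of compound 1, 5 ug/mL, and of compound 4, 98 ug/mL, a 20-fold higher number (1.29 log units; beyond the scatter)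

Among these compounds, only one pair carries this exchange, so it remains open whether the step in the physicochemical assay would hold for a pyrimidine ring on the sulfonyl sulfur, or for a pyridine ring bearing a chlorine or a methoxy group instead of trifluoromethyl. As far as these compounds go, it also remains open whether the same exchange would read alike in both assays on a compound with an aminomethyl group in place of the hydroxymethyl group on the shared core.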